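Swapping methyl for acetamido on compound 1

The compounds below may be only part of what the source reports. "The series", "measured", "known", "first", "only" and "open" are said of these compounds alone.

- compound 1 `Cc1ccc(S(=O)(=O)Nc2cc(SC(C)C(=O)N[C@@H](CC(C)C)B(O)O)c(O)c3ccccc23)cc1` (8610 nM)
- compound 2 `CC(C)C[C@H](NC(=O)C(C)Sc1cc(NS(=O)(=O)c2ccccc2)c2ccccc2c1O)B(O)O` (16500 nM; 11300 nM (2 entries))

These numbers come from a functional assay on MCF7 cells (Homo sapiens) for antiproliferative activity, read by sulforhodamine B assay, with a stated time of 72 h; a higher number here means a weaker inhibitor, a lower number a stronger inhibitor. Compound 1 has one number there and one further entry without a single number. Its value lies within the usual scatter of the values for compound 2, whose repeat readings (the several entries of compound 2 in this assay, 16500 nM; 11300 nM (2 entries)) show how much one compound can vary between measurements.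

Compound 3 `CC(=O)Nc1ccc(S(=O)(=O)Nc2cc(SC(C)C(=O)N[C@@H](CC(C)C)B(O)O)c(O)c3ccccc23)cc1` keeps the core of compound 1 and differs on an aromatic carbon, para to a large group, with acetamido in place of methyl (acetamido in place of methyl on an aromatic carbon). For the measured compounds named here, no measured pair shows what this change does, so no direction can be called, and the expected effect in this assay is none beyond the scatter. The estimate therefore means only a small expected step (a 1.2-fold higher number from compound 1 to compound 3 (0.06 log units; within the scatter)). The estimated value for compound 3 is 10000 nM, within an expected range from 3500 nM to 28000 nM.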

Compound 3, half-maximal inhibitory concentration: 8910 nM
Compound 3: the middle estimate sits 1.1-fold (0.05 log units) above what was measured; low and high end bracket the measured number.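

In this assay, putting acetamido in place of methyl on this aromatic carbon, para to a large group, gives a 1.0-fold higher number from compound 1 to compound 3 (0.01 log units; within the scatter). For the compounds shown here, this is the first measured step at this position, and it shows that the two compounds cannot be told apart in this read-out, even though acetamido has more heavy atoms than methyl and brings a hydrogen-bond donor and a hydrogen-bond acceptor. The repeat readings of a single compound show how far numbers can spread without any change in structure: the several entries of compound 2 in this assay, 16500 nM; 11300 nM (2 entries).

One step cannot show whether this position accepts other groups equally well, or whether the match between methyl and acetamido is specific to this pair. An amine or a carboxylic acid at the same carbon would test this further, as would a longer chain on the acetamido carbonyl.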